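The source may hold more compounds than are shown below. What is called first, only, known or untested is meant among the compounds shown, and "the series" means these compounds.

Compound 3 `O=C(Nc1ccc(Cl)cc1CN1C(=O)c2ccccc2C1=O)c1ccco1` gives, in an assay on CHO cells for positive allosteric modulation of metabotropic glutamate receptor 5 (Homo sapiens), read by FLIPR (a lower number here means that less compound is needed, a higher number that more compound is needed for the effect), a value of 2300 nM. Among the three numbers measured so far this stands second highest, but every neighbour sits close. Nearest is compound 2 `O=C(Nc1ccc(Cl)cc1CN1C(=O)c2ccccc2C1=O)C1CCCCC1`, which in this assay gives 1500 nM; the step of a 1.5-fold higher number from compound 2 to compound 3 (0.19 log units; within the scatter) lies within the scatter. Furthest is compound 1 `O=C(CCc1cc(Cl)ccc1NC(=O)c1ccccn1)c1ccccc1`, built on a different core, which in this assay gives 4500 nM; that value and the value of compound 3 also fall within the scatter of each other, so the three measured compounds cannot be ranked.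

Compound 4 `O=C(Nc1ccc(Cl)cc1CN1C(=O)c2ccccc2C1=O)c1ncccc1O` differs from compound 3 in one place: 3-hydroxypyridin-2-yl in place of furan-2-yl on a carbonyl carbon. Going by the values given here, only one measured step touches the same carbonyl carbon, the exchange from compound 2 to compound 3, and a 1.5-fold higher number from compound 2 to compound 3 (0.19 log units; within the scatter) stayed within the scatter. Compound 1 carries a related amide but on another core, so its value can only be noted, not turned into a step. With no measured change at this position exceeding the scatter, the expectation for compound 4 is a small shift at most. Compound 4 is therefore estimated at 2500 nM, with a range from 800 nM to 8000 nM. The step of a 1.1-fold higher number from compound 3 to compound 4 (0.04 log units; within the scatter) is expected to remain within the scatter.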

Compound 4, half-maximal effective concentration: 260 nM
Compound 4: middle estimate off by 9.6-fold (0.98 log units), on the high side; the measured number lies below the stated range.
By their numbers in this assay, from the lowest: compound 4; then compounds 2, 3 and 1 (each within the scatter of the next, the first and the last beyond it).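

The carbonyl carbon bearing the amide-type nitrogen proves to be a place where the number in this assay can move: putting 3-hydroxypyridin-2-yl in place of furan-2-yl gives an 8.8-fold lower number from compound 3 to compound 4 (0.95 log units; beyond the scatter) and so goes beyond the scatter, which the exchange of cyclohexyl for furan-2-yl did not. Set against the cyclohexyl group, the same entering group gives a 5.8-fold lower number from compound 2 to compound 4 (0.76 log units; beyond the scatter) in the same direction, so the result does not rest on a single reference compound. Since furan-2-yl and cyclohexyl stay within the scatter of each other, the shift goes with the entering group, although both steps count only as modest. Nothing measured here speaks to why this group has this effect.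

The compounds shown do not separate the hydroxy group from the ring nitrogen, as the exchange brings in both at once; a plain pyridin-2-yl or a 3-methoxypyridin-2-yl on the same carbonyl carbon would tell them apart. They also leave open whether the step would carry over to the core of compound 1.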